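Amide side chain variation on the shared core

The compounds below may be only part of what the source reports. "The series", "measured", "known", "first", "only" and "open" are said of these compounds alone.

For the measured compounds named here, compound 1 `CCC(=O)Nc1ccc(C2=NNC(=O)CC2)cc1` is the only member of the series with a numbered result: in a functional assay for inhibition, with Homo sapiens as the target (a lower number here means that less compound is needed, a higher number that more compound is needed for the effect), compound 1 gives 0.64 ug/mL. Compound 2 `Nc1cccc(C2=NNC(=O)CC2)c1` reaches only the limit of the assay, > 46.4 ug/mL in this assay. Compound 3 `CC(=O)Nc1cccc(C2=NNC(=O)CC2)c1` likewise gives only the limit, > 46.4 ug/mL in this assay. Going by the values given here, the one step among the measured compounds, a step that the two limits leave unreadable from compound 2 to compound 3, therefore cannot be read, since the limit of > 46.4 ug/mL in this assay, at which 2 of the 3 values shown sit, is where both of its values sit.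

Compound 4 `C=CCNCC(=O)Nc1ccc(C2=NNC(=O)CC2)cc1` is not yet measured. It differs from compound 1 by allylamino in place of methyl on a saturated chain carbon bound to a carbonyl carbon. Among the compounds with values here, no measured step touches this part of the molecule: the single measured step concerns the nitrogen on the aromatic ring, and its size is not readable. The expectation for this assay therefore rests on compound 1 alone, and without any comparable precedent no step beyond the scatter is assumed in either direction. Compound 4 is expected to give about 1 ug/mL in this assay, within 0.3 ug/mL to 4 ug/mL. The expected step of a 1.6-fold higher number from compound 1 to compound 4 (0.19 log units; within the scatter) is thus small, the wide range reflecting the absence of any measured change of this kind in the series.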

Compound 4, half-maximal effective concentration: about 21.5 ug/mL
Compound 4: middle estimate off by 22-fold (1.33 log units), on the low side; measured number above the stated range.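

The series now holds its first readable step, and it falls on the saturated chain carbon bound to a carbonyl carbon: in this assay, allylamino in place of methyl gives a 34-fold higher number from compound 1 to compound 4 (1.53 log units; beyond the scatter). This place is therefore not neutral to substitution, although compound 4 still gives a numbered result and does not sit at a limit of the assay. The entering group differs in several counted ways at once, with more heavy atoms, a nitrogen, a double bond outside aromatic rings and a hydrogen-bond donor and acceptor, and no measured property in the data bears on which of these matters.

From the compounds shown here alone, whether the step follows the amine nitrogen, the terminal double bond or simply the larger chain stays open, and a plain butyl chain or a saturated propylamino group at this place would begin to separate these. The step from compound 2 to compound 3 cannot be read, so the acetyl change on that nitrogen gives no size to set against the new step: the limit of > 46.4 ug/mL in this assay, at which 2 of the 4 values shown sit.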